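The source may hold more compounds than are shown below. What is called first, only, known or untested is meant among the compounds shown, and "the series" means these compounds.

Series notes. The shared core of compound 1 `O=C(CCC1C(=O)N(c2ccc(Cl)cc2)C(=O)N1Cc1ccc(Br)cc1)Nc1ccc(C(=O)NO)cc1` carries a bromo group on an aromatic carbon; in an assay on isolated protein for inhibition of histone deacetylase 7 (Homo sapiens), read by fluorescence, with stated times of 5 min and 60 min (a higher number here means a weaker inhibitor, a lower number a stronger inhibitor), compound 1 gives 6000 nM. Compound 2 `Cc1ccc(CN2C(=O)N(c3ccc(Cl)cc3)C(=O)C2CCC(=O)Nc2ccc(C(=O)NO)cc2)cc1` has methyl in place of bromo on an aromatic carbon. In this assay compound 2 gives only a limit, > 100000 nM. The step of an at least 16-fold higher number from compound 1 to compound 2 (1.22 log units; beyond the scatter) is therefore itself a lower bound, set by the limit of > 100000 nM in this assay, at which 1 of the 2 values shown sits. On the numbers shown compound 2 stands at the limit of this assay, with no measured value of its own.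

Compound 3 `O=C(CCC1C(=O)N(c2ccc(Cl)cc2)C(=O)N1Cc1ccccc1)Nc1ccc(C(=O)NO)cc1` differs from compound 2 by hydrogen in place of methyl on an aromatic carbon. For the measured compounds named here, only one measured step bears on this position, the large one from bromo to methyl, and it ran toward the smaller group; whether removing the methyl altogether continues that direction or reverses it cannot be read from two points. The step of an at least 3.3-fold lower number from compound 2 to compound 3 (0.52 log units; beyond the scatter) is therefore expected to be modest and of uncertain direction. Compound 3 is expected to give about 30000 nM in this assay, within 6000 nM to 150000 nM, with a real chance that only a limit is reported again.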

Compound 3, half-maximal inhibitory concentration: 8800 nM
Compound 3: the middle estimate sits 3.4-fold (0.53 log units) above what was measured; measured number inside the range.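

At the aromatic carbon para to a large group, the new value shows that methyl is the group out of line, not bromo: in this assay the step is an at least 11-fold lower number from compound 2 to compound 3 (1.05 log units; beyond the scatter), while the step for bromo against hydrogen is a 1.5-fold higher number from compound 1 to compound 3 (0.17 log units; within the scatter). Compound 1 and compound 3 therefore cannot be told apart here, so the earlier loss on going from bromo to methyl does not read as a trend with group size, and compound 3, with no substituent at all, goes against any such ordering. The step from methyl to hydrogen is only a lower bound, and its true size cannot be read, since compound 2 has no measured value of its own: the limit of > 100000 nM in this assay, at which 1 of the 3 values shown sits.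

The compounds shown leave open whether the loss is particular to methyl or extends to other small carbon groups at this position, such as an ethyl or a methoxy group. They also leave open whether any group here can move the number clear of the scatter in the other direction from bromo and hydrogen, for example an amine or a carboxylic acid on the same carbon.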